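Methyl in place of fluoro: compound 2 to compound 3

A few compounds are considered here, and "the series" means these few. Any claim that something is new, unique, unknown or untested is made for them only; others in the source may bear on it.

Among the measured compounds shown here, compound 2 `O=C(Nc1ccc(S(=O)(=O)Nc2ccccc2)cc1)c1ccc(Br)cc1F` gives 479 nM in a functional assay on HEK293 cells for agonist activity at probable G-protein coupled receptor 27 (Homo sapiens), read by a luciferase reporter and beta-arrestin recruitment, with a stated time of 10 min (a higher number here means that more compound is needed for the effect, a lower number that less compound is needed), and it is the only numbered value in the set. Compound 1 `O=C(Nc1ccc(S(=O)(=O)NCc2ccccc2)cc1)c1ccc(Cl)cc1Cl` is reported only as a limit of the assay, > 100000 nM, which is the limit of > 100000 nM in this assay, at which 1 of the 2 values shown sits. For the measured compounds named here, no step between two measured compounds is available, so the usual scatter alone frames what follows.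

Compound 3 `Cc1cc(Br)ccc1C(=O)Nc1ccc(S(=O)(=O)Nc2ccccc2)cc1` differs from compound 2 by methyl in place of fluoro on an aromatic carbon. One substituent is exchanged for another at an aromatic carbon, with no ring, donor, acceptor or charge added or removed. Going by the values given here, with no measured step of this kind to lean on, the expected move is small: for compound 3 the step of a 1.4-fold higher number from compound 2 to compound 3 (0.13 log units; within the scatter) is expected to stay near the scatter, the wider range allowing a modest loss. The estimate for compound 3 in this assay is 650 nM, between 150 nM and 2800 nM.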

Compound 3, half-maximal effective concentration: 851 nM
Compound 3: the middle estimate sits 1.3-fold (0.12 log units) below what was measured, and the stated range covers the measured number.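

The series now has its first readable step in this assay: a 1.8-fold higher number from compound 2 to compound 3 (0.25 log units; within the scatter), for methyl in place of fluoro on an aromatic carbon ortho to a large group. This position therefore takes either group without the read-out leaving the scatter, so compound 2 and compound 3 cannot be ordered, and the 4-bromo-2-methylphenyl compound joins the 4-bromo-2-fluorophenyl compound as a second numbered value. Nothing in hand bears on this step.

On these data alone, whether the same position would hold a methoxy group, an amine or a carboxylic acid remains open. Compound 1 is a limit of the assay, > 100000 nM, and differs from compound 2 in more than one place, so it gives no reading on this position.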